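This account rests on a few compounds, and the source may have more. Where it says the series, first, only, none or still open, it means among the compounds named here.

Measured so far: compound 1 `O=CCN1N=C(c2ccc3ccccc3c2)CC1c1cccc([N+](=O)[O-])c1` gives 3390 nM in a functional assay on OVCAR cells (Homo sapiens) for cytotoxicity, read by sulforhodamine B assay, with a stated time of 48 h; a lower number here means a stronger inhibitor, a higher number a weaker inhibitor; compound 2 `COc1ccc(C2CC(c3ccc4ccccc4c3)=NN2CC=O)cc1O` gives 2160 nM in this assay; compound 3 `O=CCN1N=C(c2ccc3ccccc3c2)CC1c1cccc(Br)c1` gives 10800 nM in this assay.

Compound 3 stands at the highest of the three numbers, with a 3.2-fold higher number from compound 1 to compound 3 (0.50 log units; beyond the scatter) and a 5.0-fold higher number from compound 2 to compound 3 (0.70 log units; beyond the scatter). Compound 4 `COc1ccc(C2CC(c3ccc4ccccc4c3)=NN2CC=O)cc1` differs from compound 3 by 4-methoxyphenyl in place of 3-bromophenyl on a saturated ring carbon. The step that bears on this is a 5.0-fold higher number from compound 2 to compound 3 (0.70 log units; beyond the scatter), since its reverse would return the methoxy group, although compound 4 keeps only that methoxy and not the hydroxy of compound 2. A lower number than compound 3, but by a smaller margin than the full reverse, is therefore expected, with a 2.4-fold lower number from compound 3 to compound 4 (0.38 log units; beyond the scatter). Compound 4 is estimated at 4500 nM, within 1800 nM to 11000 nM.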

Compound 4, half-maximal inhibitory concentration: 5790 nM
Beside the measured number, compound 4's estimate is 1.3-fold (0.11 log units) below it, within the range that was stated.
By their numbers in this assay, from the lowest: compounds 2, 1, 4 and 3 (each within the scatter of the next, the first and the last beyond it).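

In this assay, for the compounds shown here, hydrogen in place of hydroxy on an aromatic carbon gives a 2.7-fold higher number from compound 2 to compound 4 (0.43 log units; beyond the scatter) and is the only new step beyond the scatter, so at this position the hydroxy of compound 2 separates it from compound 4, which keeps the methoxy. With the hydroxy gone, 4-methoxyphenyl stays within the scatter of 3-bromophenyl, showing a 1.9-fold lower number from compound 3 to compound 4 (0.27 log units; within the scatter) as its step, and of 3-nitrophenyl, showing a 1.7-fold higher number from compound 1 to compound 4 (0.23 log units; within the scatter) as its step. Nothing measured here explains these steps.

The compounds shown leave open how an amine or a carboxylic acid on this phenyl ring would read, and whether a longer chain in place of the methoxy would keep the number of compound 4.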